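Urea series: second chloro on the aryl ring

The compounds below may be only part of what the source reports. "The series", "measured", "known", "first", "only" and "open" are said of these compounds alone.

Measured so far in an ADME assay on the whole organism with Oryza sativa as the target, tested at 10 uM; on this read-out higher numbers stand for a weaker effect at the one concentration tested and lower numbers for a stronger effect:
compound 1, `CCc1cccc(NC(=O)N[C@@H](C)c2ccccc2)c1`, gives 86%
compound 2, `CCOC(=O)c1cccc(NC(=O)N[C@@H](C)c2ccccc2)c1`, gives 96%
compound 3, `C[C@H](NC(=O)Nc1cccc(Cl)c1)c1ccccc1`, gives 103%

Compound 3 stands at the top of the three numbers in this assay. Its gap to compound 1 is beyond the scatter, a number 17 percentage points higher from compound 1 to compound 3 (beyond the scatter), while its gap to compound 2 is within it, a number 7 percentage points higher from compound 2 to compound 3 (within the scatter); the ethyl-to-ethoxycarbonyl exchange, a number 10 percentage points higher from compound 1 to compound 2 (within the scatter), also stays within the scatter. So the three measured compounds sit in a narrow band near the upper end, and only compound 1 separates clearly.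

Compound 4, `C[C@H](NC(=O)Nc1cc(Cl)cc(Cl)c1)c1ccccc1`, is the next member. Compared with compound 3 the structural change is a single one: chloro in place of hydrogen on an aromatic carbon

Going by the values given here, none of the measured steps adds a second chloro to a ring already carrying one; the closest precedent is the chloro-for-ethyl exchange, a number 17 percentage points higher from compound 1 to compound 3 (beyond the scatter), which was modest and already brought the number to the top of the band. A further group of the same kind at a second aromatic position is therefore expected to move compound 4 little: the estimated step is no change at the digits printed from compound 3 to compound 4 (within the scatter), not beyond the scatter. For compound 4 in this assay the estimate is 103%, with a range from 90% to 113%.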

Compound 4, a percentage reported as activity, at one concentration (the size of the read-out at that concentration, not a potency): 99%
Estimate against measurement, compound 4: 4 percentage points above, within the range that was stated.
By their numbers in this assay, from the lowest: compounds 1, 2, 4 and 3 (each within the scatter of the next, the first and the last beyond it).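

In this assay, going by these compounds alone, the second chloro, on an aromatic carbon meta to a chloro group, gives a number 4 percentage points lower from compound 3 to compound 4 (within the scatter) and so marks the first step that adds a group instead of exchanging one. The earlier compounds shown here varied only the group held at a single aromatic carbon, whereas this result shows that a further aromatic carbon of the same ring can take a chloro without the read-out separating compound 4 from compound 3. Nothing measured in the series speaks to a cause for this result.

Within the data shown here, still open is whether a different group at this second aromatic carbon, such as a methoxy group, an amine or a carboxylic acid, would leave the number equally unmoved, and whether a second chloro would behave the same way alongside the ethyl group of compound 1, the one compound whose number stands clearly apart from that of compound 3. Also open is how far the number responds to any change on the unsubstituted phenyl ring or on the urea itself, since every compound shown keeps both unchanged.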